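This account rests on a few compounds, and the source may have more. Where it says the series, first, only, none or still open, it means among the compounds named here.

Measured so far:
- compound 1, `O=C(O)Cc1sc(NC(=O)c2ccccc2)nc1-c1ccc(Cl)cc1`, in an in vitro functional assay on HEK285-7 cells for antagonist activity at prostaglandin D2 receptor 2 (Homo sapiens), read by BRET and beta-arrestin recruitment (on this read-out higher numbers stand for weaker inhibition and lower numbers for stronger inhibition), gives 870 nM
- compound 2, `O=C(O)Cc1sc(C(c2ccccc2)c2ccc(Cl)cc2)nc1-c1ccc(Cl)cc1`, in this assay gives 75 nM
- compound 3, `O=C(O)Cc1sc(C(c2ccc(F)cc2)c2ccc(F)cc2)nc1-c1ccc(Cl)cc1`, in this assay gives 180 nM

Compound 3 holds the second highest of the three numbers. Its nearest neighbour is compound 2, which sits lower by a margin beyond the scatter; compound 1 lies furthest away, higher, also beyond the scatter. For the measured compounds named here, no two measured compounds differ in only one place, so no single step has yet been quantified in this assay.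

Compound 4, `O=C(O)Cc1sc(C(c2ccc(F)cc2)c2ccc(F)cc2)nc1-c1ccnc(N2CCC2)c1`, differs from compound 3 in one place: 2-(azetidin-1-yl)pyridin-4-yl in place of 4-chlorophenyl on an aromatic carbon. Going by the values given here, nothing among the measured compounds speaks to this change, so the step in this assay has no anchor; the expectation is a modest weakening, possibly none beyond the scatter. Compound 4 is expected near 300 nM, with a range of 100 nM to 1000 nM. This corresponds to an expected step of a 1.7-fold higher number from compound 3 to compound 4 (0.22 log units; within the scatter).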

Compound 4, half-maximal inhibitory concentration: > 100000 nM
Compound 4 gave a limit, no number; the forecaster's own chance of this, stated with the estimate: 5%; at least 330-fold (2.52 log units) between middle value and limit.
By their numbers in this assay, from the lowest: compound 2; then compound 3; then compound 1. At a limit, above all of these: compound 4.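

Compound 4 gives only a limit of the assay, > 100000 nM, not a number. In this assay, the aromatic carbon next to the ring nitrogen proves far from tolerant of every group: 2-(azetidin-1-yl)pyridin-4-yl in place of 4-chlorophenyl gives an at least 550-fold higher number from compound 3 to compound 4 (2.74 log units; beyond the scatter), the first single change quantified in this series.

The compounds shown do not separate the contribution of the pyridine ring from that of the azetidine. An unsubstituted pyridin-4-yl, or a phenyl bearing azetidine, at this position would pull the two apart.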